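The source may hold more compounds than are shown below. What is called first, only, known or untested is meant among the compounds shown, and "the series" means these compounds.

Compound 1 `Cc1coc2cc(OCC(=O)Nc3cccc(NC(=O)c4ccc(N(C)C)cc4)c3)ccc2c1=O` gives in an assay on isolated protein for inhibition of Rho-associated protein kinase 1 (Homo sapiens), read by scintillation counting, radiometric assay and 33P incorporation, with a stated time of 40 min, in the presence of a further agent that is not named here (a higher number here means a weaker inhibitor, a lower number a stronger inhibitor), only the limit > 10000 nM. Compound 2 `CCCC(=O)Nc1cccc(NC(=O)COc2ccc3c(=O)ccoc3c2)c1` gives 1430 nM. Compound 3 `O=C(COc1ccc2c(=O)ccoc2c1)Nc1cccc(NC(=O)c2ccc([N+](=O)[O-])cc2)c1` gives 67 nM.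

Compound 3 thus holds the lowest of the two numbers; its nearest neighbour is compound 2, and the step of a 21-fold lower number from compound 2 to compound 3 (1.33 log units; beyond the scatter) is large, the exchange being 4-nitrophenyl in place of propyl on a carbonyl carbon. Compound 4 `Nc1ccc(C(=O)Nc2cccc(NC(=O)COc3ccc4c(=O)ccoc4c3)c2)cc1` differs from compound 3 by amino in place of nitro on an aromatic carbon. Among the measured compounds shown here, the single measured step concerns the same group, but it introduces the whole 4-nitrophenyl and alters no substituent on that ring, so the size of the move from nitro to amino is uncertain and may fall within the scatter. A modest weakening is expected, a 2.2-fold higher number from compound 3 to compound 4 (0.35 log units; beyond the scatter). Compound 4 is therefore estimated at 150 nM, with a range of 40 nM to 600 nM.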

Compound 4, half-maximal inhibitory concentration: 802 nM
Estimate against measurement, compound 4: 5.3-fold (0.73 log units) below; the measured number lies above the stated range.
By their numbers in this assay, from the lowest: compound 3; then compounds 4 and 2 (each within the scatter of the next). At a limit, above all of these: compound 1.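

The para substituent, not the phenyl ring alone, decides the level in this pair: with a 12-fold higher number from compound 3 to compound 4 (1.08 log units; beyond the scatter), amino in place of nitro is itself a large move, which the earlier step could not separate from the arrival of the ring. With a 1.8-fold lower number from compound 2 to compound 4 (0.25 log units; within the scatter), 4-aminophenyl and propyl on the carbonyl carbon cannot be told apart, so the 4-aminophenyl ring brings no gain beyond the scatter. No measured property at hand bears on this difference between nitro and amino.

Going by these compounds, whether a nitrile or a carboxylic acid at this position would hold the level seen with nitro remains open.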